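A few compounds are considered here, and "the series" means these few. Any claim that something is new, unique, unknown or untested is made for them only; others in the source may bear on it.

Compound 1 `O=C(CN(c1nc(Cl)nc2[nH]cnc12)C1CC1)NCC(=O)OCc1ccccc1` gives 18% in a functional assay on the whole organism (Tail, strain ICR) with Mus musculus as the target, in the tail flick test, with a stated time of 150 min, at a dose of 25 umol/kg by the oral route; a higher number here means a stronger effect of the compound at the dose given, a lower number a weaker effect. Compound 2 `CSCC[C@H](NC(=O)CN(c1ncnc2c1ncn2C1CCCCO1)C1CC1)C(=O)OCc1ccccc1` gives 17.5%, within the scatter of compound 1, while compound 3 `C[C@H](NC(=O)CN(c1ncnc2c1ncn2C1CCCCO1)C1CC1)C(=O)OCc1ccccc1` gives 6.01%, so compound 1 stands at the top of the three numbers but is separated beyond the scatter only from compound 3. Compound 4 `C[C@@H](O)[C@H](NC(=O)CN(c1nc(Cl)nc2[nH]cnc12)C1CC1)C(=O)OCc1ccccc1` differs from compound 1 by 1-hydroxyethyl in place of hydrogen on a saturated chain carbon bound to an amide-type nitrogen and a carbonyl carbon. Going by the values given here, one measured step concerns the same place: a number 11.5 percentage points lower from compound 2 to compound 3 (beyond the scatter), in the core of compound 2, where a side chain gave way to hydrogen. Read in reverse, putting a side chain onto that carbon, it suggests a modest rise, although the entering group and the core differ. The change from compound 1 to compound 4 is therefore expected to be a number 8 percentage points higher from compound 1 to compound 4 (within the scatter). Compound 4 is estimated at 26%, with a range from 12% to 40%.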

Compound 4, a percentage reported as activity, at one dose (the size of the read-out at that dose, not a potency): 12.8%
Compound 4: middle estimate off by 13.2 percentage points, on the high side, within the range that was stated.
By their numbers in this assay, from the lowest: compounds 3, 4, 2 and 1 (each within the scatter of the next, the first and the last beyond it).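

In this assay, placing 1-hydroxyethyl on this carbon of the core of compound 1 gives a number 5.2 percentage points lower from compound 1 to compound 4 (within the scatter), so here the group is not separated from hydrogen. Going by these compounds alone, the only earlier step at this place, a number 11.5 percentage points lower from compound 2 to compound 3 (beyond the scatter), lay beyond the scatter, but it concerned a different group on a different core, and a side chain at this carbon therefore does not have a single reading across the compounds. Nothing available explains this difference between the two steps. From the compounds shown here alone, whether an amine, a carboxylic acid or a longer chain on this carbon of the core of compound 1 would move the read-out beyond the scatter remains open.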